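This account rests on a few compounds, and the source may have more. Where it says the series, first, only, none or still open, it means among the compounds named here.

Series notes. Compound 1 `COc1ccc(-n2c(S)nnc2-c2cc(OC)c(OC)c(OC)c2)cc1` carries hydrogen on the sulfur, and in a functional assay on HepG2 cells (Homo sapiens) for inhibition, read by MTT assay, with a stated time of 48 h (on this read-out lower numbers stand for stronger inhibition and higher numbers for weaker inhibition), compound 1 gives 57500 nM. Compound 2 `COc1ccc(-n2c(SCc3ccc(C)cc3)nnc2-c2cc(OC)c(OC)c(OC)c2)cc1` gives 31600 nM, which is a 1.8-fold lower number from compound 1 to compound 2 (0.26 log units; within the scatter). For the measured compounds named here, compound 3 `COc1ccc(-n2c(SCC(=O)c3ccc(F)cc3)nnc2-c2cc(OC)c(OC)c(OC)c2)cc1` gives 10700 nM, the lowest of the three numbers so far. It stands apart from both others: a 5.4-fold lower number from compound 1 to compound 3 (0.73 log units; beyond the scatter) and a 3.0-fold lower number from compound 2 to compound 3 (0.47 log units; beyond the scatter).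

Compound 4 `COc1ccc(-n2c(SCC(=O)C3CC3)nnc2-c2cc(OC)c(OC)c(OC)c2)cc1` keeps the shared core and the carbonyl, with cyclopropyl in place of 4-fluorophenyl on a carbonyl carbon. Going by the values given here, no measured step changes this group alone, so the evidence is indirect. The closest guide is a 3.0-fold lower number from compound 2 to compound 3 (0.47 log units; beyond the scatter), which also changes the group on the saturated chain carbon bound to the sulfur. Among the compounds with values here, with only three measured compounds, neither the size nor the direction is firmly set. A modest move toward a higher number in this assay is expected, and the estimated step is a 2.2-fold higher number from compound 3 to compound 4 (0.35 log units; beyond the scatter). For compound 4 the estimate is 24000 nM, with an expected range from 10000 nM to 55000 nM.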

Compound 4, half-maximal inhibitory concentration: > 60000 nM
Compound 4: a limit, no number; the forecaster's own chance of this, stated with the estimate: 5%; middle value at least 2.5-fold (0.39 log units) away from the limit.
By their numbers in this assay, from the lowest: compound 3; then compounds 2 and 1 (each within the scatter of the next). At a limit, above all of these: compound 4.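

Cyclopropyl in place of 4-fluorophenyl on a carbonyl carbon is the first change shown at this position, and in this assay it gives an at least 5.6-fold higher number from compound 3 to compound 4 (0.74 log units; beyond the scatter); compound 4 keeps the carbonyl, so the carbonyl alone does not account for the lower number of compound 3. Compound 4 has no clear separation from the other two compounds, with an at least 1.8-fold higher number from compound 2 to compound 4 (0.27 log units; that floor lies within the scatter) and an at least 1.0-fold higher number from compound 1 to compound 4 (0.01 log units; that floor lies within the scatter). Compound 4 gives a limit, not a number: the limit of > 60000 nM in this assay, at which 1 of the 4 values shown sits.

As far as these compounds go, the size of all three steps remains open, and so does whether compound 4 truly differs from compound 1 or compound 2. Also open, from the compounds shown here alone, is how an unsubstituted phenyl, a pyridine ring or a longer alkyl chain on the carbonyl carbon would compare with 4-fluorophenyl.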